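This account rests on a few compounds, and the source may have more. Where it says the series, first, only, none or still open, it means among the compounds named here.

Compound 1, `COc1ccc(OC)c(-c2cc(-c3ccc(C(=O)N4CCCC4)s3)on2)c1`, is measured in a functional assay on PC-3 cells (Homo sapiens) for cytotoxicity, read by XTT assay, with a stated time of 72 h; on this read-out lower numbers stand for stronger inhibition and higher numbers for weaker inhibition. In this assay compound 1 gives only a limit, > 30000 nM, and no number. Compound 2, `O=C1C=CC(=O)C(c2cc(-c3ccc(C(=O)NCC4CC4)s3)on2)=C1`, is the other measured compound. In this assay compound 2 likewise reports only a limit, > 30000 nM. Compound 1 therefore stands at the limit of > 30000 nM in this assay, at which 2 of the 2 values shown sit. For the measured compounds named here, no measured pair of compounds differs in just one place, so no measured step is available to lean on. Compound 3, `COc1ccc(OC)c(-c2cc(-c3ccc(C(=O)NC4CC4)s3)on2)c1`, differs from compound 1 by cyclopropylamino in place of pyrrolidin-1-yl on a carbonyl carbon. The step from compound 1 to compound 3 is expected to be none beyond the scatter in this assay, with compound 3 most likely remaining at the limit. Given that compound 1 sits at the limit of > 30000 nM in this assay, at which 2 of the 2 values shown sit, compound 3 is expected to give 45000 nM, with an estimated range from 20000 nM to 100000 nM. The step this estimate implies, a step that the limit leaves unreadable from compound 1 to compound 3, is expected to stay within the scatter.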

Compound 3, half-maximal inhibitory concentration: 7800 nM
Compound 3: the middle estimate sits 5.8-fold (0.76 log units) above what was measured; measured number below the stated range.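

In this assay, cyclopropylamino in place of pyrrolidin-1-yl on a carbonyl carbon gives an at least 3.8-fold lower number from compound 1 to compound 3 (0.58 log units; beyond the scatter), which shows that this place on the core of compound 1 responds to a change of the amine part. Compound 1 gives only a limit, so the step marks a smallest size and not an exact one. Compound 3 is the first compound here to give a number rather than a limit: the limit of > 30000 nM in this assay, at which 2 of the 3 values shown sit.

The compounds shown do not tell whether the step goes with the amide hydrogen that enters or with the change from a five-membered to a three-membered ring. As far as these compounds go, it also remains open how an open-chain ethylamino or a dimethylamino group on the same carbonyl carbon would compare with cyclopropylamino.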